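Working notes: a bromo on compound 2

This account rests on a few compounds, and the source may have more. Where it says the series, first, only, none or still open, it means among the compounds named here.

Measured so far:
compound 1 `CC1(C)OC(/C=C/c2ccsc2)=CC1=O` gives 4 mg/kg
compound 2 `CC1(C)OC(/C=C/c2ccccc2)=CC1=O` gives 17 mg/kg

In a functional assay on the whole organism for inhibition, with Rattus norvegicus as the target, with a stated time of 1 h (on this read-out higher numbers stand for an effect only at larger amounts of compound and lower numbers for an effect already at smaller amounts), compound 2 at 17 mg/kg has the higher of the two numbers, and compound 1 at 4 mg/kg lies lower by more than the usual scatter. Compound 3 `CC1(C)OC(/C=C/c2ccc(Br)cc2)=CC1=O` differs from compound 2 in one place, with bromo in place of hydrogen on an aromatic carbon, para to a large group (bromo in place of hydrogen on an aromatic carbon). Going by the values given here, no measured pair shows this change. The expectation therefore starts from compound 2 at 17 mg/kg and no step beyond the scatter is expected in this assay in either direction. The expected 1.2-fold lower number from compound 2 to compound 3 (0.08 log units; within the scatter) stays within the scatter. For compound 3 the estimated value is 14 mg/kg with an expected range from 5 mg/kg to 40 mg/kg for the measurement.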

Compound 3, dose for half-maximal effect: 18 mg/kg
Compound 3: the middle estimate sits 1.3-fold (0.11 log units) below what was measured; measured number inside the range.
By their numbers in this assay, from the lowest: compound 1; then compounds 2 and 3 (each within the scatter of the next).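

In this assay, bromo in place of hydrogen on an aromatic carbon, para to a large group, gives a 1.1-fold higher number from compound 2 to compound 3 (0.02 log units; within the scatter) and so stays within the scatter. Going by these compounds alone, the earlier compounds carry no substituent at this place, so only this pair shows that the position accepts a single bromine atom without a step that can be told from the scatter. No measurement at hand offers an explanation for this result.

As far as these compounds go, whether the same tolerance extends to other groups at this position remains open: an amine, a carboxylic acid or a longer chain could give a quite different number from the one seen with bromo. Also open, from the compounds shown here alone, is whether bromo behaves in the same way on the core of compound 1 or at another carbon of the six-membered aromatic ring.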